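Working notes on the 2-aryl substituent series

The source may hold more compounds than are shown below. What is called first, only, known or untested is meant among the compounds shown, and "the series" means these compounds.

Compound 2 `CC1C=C(c2nc(C(F)(F)F)ccc2CNC(=O)C(C)c2ccc(NS(C)(=O)=O)c(F)c2)CCC1` gives 0.2 nM in an assay on CHO cells for antagonist activity at transient receptor potential cation channel subfamily V member 1 (Homo sapiens), read by FLIPR and calcium flux (a lower number here means a stronger inhibitor, a higher number a weaker inhibitor), and holds the lowest number of the two measured compounds. Compound 1 `CCCCCc1nc(C(F)(F)F)ccc1CNC(=O)C(C)c1ccc(NS(C)(=O)=O)c(F)c1` gives 1 nM in this assay. Among the measured compounds shown here, the single measured step, a 5.0-fold lower number from compound 1 to compound 2 (0.70 log units; beyond the scatter), accompanies the exchange of pentyl for 3-methylcyclohex-1-en-1-yl. Compound 3 `CC(C)=Cc1nc(C(F)(F)F)ccc1CNC(=O)C(C)c1ccc(NS(C)(=O)=O)c(F)c1` differs from compound 2 by 2-methylprop-1-en-1-yl in place of 3-methylcyclohex-1-en-1-yl on an aromatic carbon, leaving no ring but keeping one double bond outside aromatic rings. For the measured compounds named here, no measured step covers exactly this change. Compound 3 is expected to give back part of that gain, a modest rise in number, a 3.0-fold higher number from compound 2 to compound 3 (0.48 log units; beyond the scatter). Compound 3 is therefore estimated at 0.6 nM in this assay, within 0.2 nM to 2 nM.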

Compound 3, inhibition constant: 11.5 nM
The estimate for compound 3 lay 19-fold (1.28 log units) below the measured number; measured number outside the range, above it.
By their numbers in this assay, from the lowest: compound 2; then compound 1; then compound 3.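

Keeping the double bond outside aromatic rings while losing the ring comes with a 58-fold higher number from compound 2 to compound 3 (1.76 log units; beyond the scatter) in this assay, so that double bond alone does not hold the low number at this position. The open-chain 2-methylprop-1-en-1-yl group also falls behind saturated pentyl, with a 12-fold higher number from compound 1 to compound 3 (1.06 log units; beyond the scatter), so among these compounds the double bond does not track with the lower number. Nothing available accounts for either step.

From the compounds shown here alone, whether the ring or the overall size of the group matters more remains open. A cyclohexyl or 2-methylpropyl group here would help separate the two.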